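The source may report more compounds than this note shows. Statements on the series, on what has been measured and on what is new or still open speak of the compounds shown alone.

Measured so far:
compound 1 `CC(NC(=O)N1C(=O)c2ccccc2S1(=O)=O)c1ccccc1`: > 166 h
compound 2 `COc1cccc(CNC(=O)N2C(=O)c3ccccc3S2(=O)=O)c1`: > 166 h

Both values come from a physicochemical assay for pharmacokinetics; on this read-out higher numbers stand for a longer-lived compound and lower numbers for a shorter-lived compound. For compound 1 the value > 166 h is a limit of the assay and not a number. For compound 2 the value > 166 h is likewise a limit of the assay. Compound 2 thus stands at the upper edge of what this assay reports, and compound 1 sits there as well (the limit of > 166 h in this assay, at which 2 of the 2 values shown sit). Within the data shown here, no step between measured compounds that differ in one place is available, and the two limits show only that neither compound fell short of them.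

Compound 3 `O=C(NCc1cccc(Br)c1)N1C(=O)c2ccccc2S1(=O)=O` is not yet measured. It differs from compound 2 in one place: bromo in place of methoxy on an aromatic carbon, read one bond further out, 3-methoxyphenyl to 3-bromophenyl. Among the measured compounds shown here, nothing among the measured compounds shows how this change bears on this assay. The step that the limit leaves unreadable from compound 2 to compound 3 is expected to be none beyond the scatter. Compound 3 is expected to give 200 h in this assay, within 80 h to 500 h, and most probably reported again only as a limit.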

Compound 3, half-life: > 166 h
Compound 3 ended at the assay's limit; the forecaster's own chance of this, stated with the estimate: 85%; the middle value lies beyond the limit too.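

In this assay compound 3 gives > 166 h, which is a limit of the assay and not a number. No step from compound 2 to compound 3 can be read, as both sit at the same limit: the limit of > 166 h in this assay, at which 3 of the 3 values shown sit.

As far as these compounds go, the actual half-lives of compound 1, compound 2 and compound 3 remain open, as does any effect of bromo in place of methoxy on this assay.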